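Swapping the Aryl Group on the Ring Nitrogen

The compounds below may be only part of what the source reports. "The series", "measured", "known", "first", "only" and "open" are said of these compounds alone.

Compound 1 `N#CC1=C(N)Oc2c(c3nc4ccccc4nc3c3ccccc23)C12C(=O)N(Cc1cnnn1-c1ccccc1Br)c1ccccc12` and compound 2 `N#CC1=C(N)Oc2c(c3nc4ccccc4nc3c3ccccc23)C12C(=O)N(Cc1cnnn1-c1ccc([N+](=O)[O-])cc1)c1ccccc12` share the same large core and differ only in the aromatic group carried on an aromatic nitrogen: a 2-bromophenyl in compound 1, a 4-nitrophenyl in compound 2. In a functional assay on A549 cells (Homo sapiens) for antiproliferative activity, read by MTT assay, with a stated time of 48 h (a lower number here means a stronger inhibitor, a higher number a weaker inhibitor), compound 1 gives > 50000 nM, which is a limit of the assay rather than a measured number. In this assay compound 2 gives > 50000 nM, again a limit. The step that the two limits leave unreadable from compound 1 to compound 2 therefore has no readable size. The only firm point is the limit of > 50000 nM in this assay, at which 2 of the 2 values shown sit, so compound 2 stands at the edge of what this assay can report.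

Compound 3 `Cc1ccc(-n2nncc2CN2C(=O)C3(C(C#N)=C(N)Oc4c3c3nc5ccccc5nc3c3ccccc43)c3ccccc32)cc1C` continues the same series of changes: 3,4-dimethylphenyl in place of 4-nitrophenyl on an aromatic nitrogen. Within the data shown here, no measured step bears on this change with a usable size, since the one step available is unreadable. With both measured compounds at the limit, compound 3 is expected to behave alike, and the step that the limit leaves unreadable from compound 2 to compound 3 is estimated to lie within the scatter. Compound 3 is estimated at 60000 nM, with a range from 20000 nM to 200000 nM, and another limit is expected as the likeliest outcome.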

Compound 3, half-maximal inhibitory concentration: > 50000 nM
Compound 3 gave a limit, no number (the forecaster's own chance of this, stated with the estimate: 80%); the middle value does not contradict the limit.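

No step can be read between compound 1, compound 2 and compound 3 in this assay because all three stop at the same limit, which is not a measured number: the limit of > 50000 nM in this assay, at which 3 of the 3 values shown sit. The compounds shown leave open whether any aryl group at this place gives a measurable effect on these cells, and how the three groups would rank.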